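Iodo in Place of Isopropyl: Compound 4 Awaits Its Number

A few compounds are considered here, and "the series" means these few. Any claim that something is new, unique, unknown or untested is made for them only; others in the source may bear on it.

Three compounds have been measured in a functional assay on M21 cells (Homo sapiens) for antiproliferative activity, read by sulforhodamine B assay, with a stated time of 48 h; a lower number here means a stronger inhibitor, a higher number a weaker inhibitor:
Compound 1 `CCC(=O)Nc1ccc(S(=O)(=O)Oc2ccccc2I)cc1` gives 11000 nM.
Compound 2 `CC(C)(C)C(=O)Nc1ccc(S(=O)(=O)Oc2ccccc2I)cc1` gives 8300 nM.
Compound 3 `CC(C)c1ccccc1OS(=O)(=O)c1ccc(NC(=O)CCl)cc1` gives 3900 nM.

Compound 3 stands lowest of the three, with compound 2 and compound 1 both higher by more than the scatter. For the measured compounds named here, the only single-point step measured so far, a 1.3-fold lower number from compound 1 to compound 2 (0.12 log units; within the scatter), concerns the group on the carbonyl carbon and falls within the scatter. Compound 4 `O=C(CCl)Nc1ccc(S(=O)(=O)Oc2ccccc2I)cc1` differs from compound 3 by iodo in place of isopropyl on an aromatic carbon. Going by the values given here, no measured step bears on this exchange; compounds 1 and 2 carry the iodo but a different acyl group, so they give no isolated reading of it. The step is therefore expected to be small, a 1.3-fold higher number from compound 3 to compound 4 (0.11 log units; within the scatter), and compound 4 is estimated at 5000 nM, within 1500 nM to 15000 nM.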

Compound 4, half-maximal inhibitory concentration: 3900 nM
Beside the measured number, compound 4's estimate is 1.3-fold (0.11 log units) above it; the range from low to high includes it.
By their numbers in this assay, from the lowest: compounds 3 and 4 (each within the scatter of the next); then compounds 2 and 1 (each within the scatter of the next).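

In this assay, iodo in place of isopropyl on an aromatic carbon ortho to a large group gives no change at the digits printed from compound 3 to compound 4 (within the scatter), so this exchange leaves the number unmoved when chloromethyl sits on the carbonyl carbon. With iodo held fixed, the group on the carbonyl carbon does matter: a 2.1-fold lower number from compound 2 to compound 4 (0.33 log units; beyond the scatter) follows chloromethyl in place of tert-butyl, and a 2.8-fold lower number from compound 1 to compound 4 (0.45 log units; beyond the scatter) follows chloro in place of methyl. No measurement available here offers an explanation for these results. Still open, going by these compounds, is how a methoxy group or a hydroxyl at that aromatic carbon would read, and whether an amine in place of the chloro would keep the number of compound 4.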